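From compound 3 to compound 4: a cyclopentyl swap

The compounds below may be only part of what the source reports. "The series", "measured", "known", "first", "only" and "open" are said of these compounds alone.

In a physicochemical assay for solubility, read by HPLC, using the shake flask method, in phosphate buffer, with a stated time of 20 h, at pH 6.5 (on this read-out higher numbers stand for higher solubility and lower numbers for lower solubility), compound 3 `CN1CCN(CC2CCN(c3nccc4[nH]c(-c5cccc(OCCN)c5)nc34)CC2)CC1` gives 200000 nM. That value lies within the scatter of compound 1 `CN1CCN(CC2CCN(c3nccc4[nH]c(-c5ccc(F)c(F)c5)nc34)CC2)CC1` at 195000 nM and of compound 2 `CN1CCN(C2CCN(c3nccc4[nH]c(C5CCCC5)nc34)CC2)CC1` at 170000 nM, so the three cannot be ranked. Compound 4 `CN1CCN(CC2CCN(c3nccc4[nH]c(C5CCCC5)nc34)CC2)CC1` has cyclopentyl in place of 3-(2-aminoethoxy)phenyl on an aromatic carbon. Within the data shown here, the only measured step at this place, a 1.0-fold higher number from compound 1 to compound 3 (0.01 log units; within the scatter), exchanges 3,4-difluorophenyl for 3-(2-aminoethoxy)phenyl and stays within the scatter. Compound 2 also carries cyclopentyl and gives 170000 nM. One step is thin evidence, but no shift beyond the scatter is expected. The expected step is a 1.1-fold lower number from compound 3 to compound 4 (0.05 log units; within the scatter). Compound 4 is estimated at 180000 nM, with an expected range of 100000 nM to 230000 nM.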

Compound 4, solubility: < 5000 nM
Compound 4 gave a limit, no number; the forecaster's own chance of this, stated with the estimate: 15%; middle value at least 36-fold (1.55 log units) from the limit.
By their numbers in this assay, from the lowest: compounds 2, 1 and 3 (each within the scatter of the next). At a limit, below all of these: compound 4.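

The place between the two ring nitrogen atoms is not indifferent after all: cyclopentyl there gives an at least 40-fold lower number from compound 3 to compound 4 (1.60 log units; beyond the scatter) and an at least 39-fold lower number from compound 1 to compound 4 (1.59 log units; beyond the scatter). Cyclopentyl alone does not settle the outcome, however, as (4-methylpiperazin-1-yl)methyl in place of 4-methylpiperazin-1-yl gives an at least 34-fold lower number from compound 2 to compound 4 (1.53 log units; beyond the scatter). Compound 4 gave only a limit in this assay: the limit of < 5000 nM in this assay, at which 1 of the 4 values shown sits.

On these data alone, the true value of compound 4 stays unknown. Also open, as far as these compounds go, is whether a cyclohexyl ring or a butyl chain at this place, alongside (4-methylpiperazin-1-yl)methyl, would behave like cyclopentyl or like 3,4-difluorophenyl.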